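Dropping the chloro of compound 3: what to expect

The compounds below may be only part of what the source reports. "The series", "measured", "known", "first", "only" and "open" are said of these compounds alone.

Compound 3 `Cc1ccc(Nc2nc(C)c(C(=O)/C=C/c3ccccc3Cl)s2)cc1` is one of three measured members of this series. In a functional assay on Bel-7402 cells (Homo sapiens) for cytotoxicity, read by MTT assay (a lower number here means a stronger inhibitor, a higher number a weaker inhibitor), compound 3 gives only a limit, > 25000 nM. Compound 1 `Cc1nc(Nc2cccc(Cl)c2)sc1C(=O)/C=C/c1ccccc1` likewise gives only a limit in this assay, > 25000 nM. Compound 2 `Cc1nc(Nc2ccc(Cl)c(Cl)c2)sc1C(=O)/C=C/c1ccccc1` gives 21500 nM in this assay. Compound 3 thus stands with compound 1 at the limit of > 25000 nM in this assay, at which 2 of the 3 values shown sit, and its value does not set it apart from compound 2.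

Compound 4 `Cc1ccc(Nc2nc(C)c(C(=O)/C=C/c3ccccc3)s2)cc1` differs from compound 3 by hydrogen in place of chloro on an aromatic carbon. Among the measured compounds shown here, the only measured single-point step concerns a chloro on the other six-membered aromatic ring, an at least 1.1-fold lower number from compound 1 to compound 2 (0.06 log units; that floor lies within the scatter), and it does not rise above the scatter. For the measured compounds named here, no measured pair addresses a chloro at the place changed here. The reviewer therefore expects no step beyond the scatter, the estimated step being a step that the limit leaves unreadable from compound 3 to compound 4. Compound 4 is expected to give 30000 nM in this assay, with a range from 12000 nM to 80000 nM, most probably reported again only as a limit.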

Compound 4, half-maximal inhibitory concentration: > 25000 nM
Compound 4 gave a limit, no number; the forecaster's own chance of this, stated with the estimate: 70%; the middle value does not contradict the limit.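

Taking the chloro off the 2-chlorophenyl ring leaves compound 4 at a limit in this assay, just as compound 3 was, so neither its step from compound 3 nor its step from compound 1 can be read, and this position shows no readable effect of the chloro. Against compound 2, the only compound with a number, the change to 4-methylphenyl on the nitrogen gives an at least 1.1-fold higher number from compound 2 to compound 4 (0.06 log units; that floor lies within the scatter). The plain phenyl compound thus brings no sign of activity at this position, and the set now gathers at one end of the scale: the limit of > 25000 nM in this assay, at which 3 of the 4 values shown sit.

On these data alone, whether the chloro at this place matters at all stays open, as a limit on both sides hides any step. Also open, as far as these compounds go, is whether a methoxy group, an amine or a carboxylic acid on this ring would bring a number into this assay.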